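Side-chain swap on the aryl ether of the shared core

The compounds below may be only part of what the source reports. "The series", "measured", "known", "first", "only" and "open" are said of these compounds alone.

Measured so far:
- compound 1 `COc1cc(OC)c2c(=O)cc(-c3ccc(OCCF)cc3)oc2c1`: "not active" (no number reported)
- compound 2 `COc1cc(OC)c2c(=O)cc(-c3ccc(OC4CCNCC4)cc3)oc2c1`: 21%

Among the compounds with values here, in a functional assay (Homo sapiens) for antiproliferative activity, read by resazurin assay, with a stated time of 48 h, tested at 10 uM (a higher number here means a stronger effect of the compound at the concentration tested, a lower number a weaker effect), compound 2 gives 21%, the only number reported for the series. Compound 1 is recorded as "not active" (no number reported) without a figure. Compound 3 `COc1cc(OC)c2c(=O)cc(-c3ccc(OCC(O)CN(C)C)cc3)oc2c1` differs from compound 2 by 3-(dimethylamino)-2-hydroxypropyl in place of piperidin-4-yl on an oxygen on an aromatic ring. Within the data shown here, no step between two measured compounds is available, so the size of this change has no measured precedent; 3-(dimethylamino)-2-hydroxypropyl in place of piperidin-4-yl on an oxygen on an aromatic ring is expected to leave the read-out in this assay about where compound 2 stands, with no step beyond the scatter in either direction. The expected step is a number 1 percentage points higher from compound 2 to compound 3 (within the scatter). Compound 3 is expected to give 22%, within 5% to 42%.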

Compound 3, a percentage reported as inhibition, at one concentration (the size of the read-out at that concentration, not a potency): 60%
Compound 3: the middle estimate sits 38 percentage points below what was measured; measured number outside the range, above it.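

Swapping piperidin-4-yl for 3-(dimethylamino)-2-hydroxypropyl on the oxygen on the aromatic ring gives, in this assay, a number 39 percentage points higher from compound 2 to compound 3 (beyond the scatter); this is the first measured step in the series, and it shows that the read-out at this position responds to the side chain. The change removes the ring and adds the hydroxyl in a single step, so the two cannot be separated here. Nothing available bears on the reason for the step.

Still open, going by these compounds, is whether the step follows the hydroxyl, the open chain or the dimethylamino end. A plain 3-(dimethylamino)propyl chain, or a morpholine in place of the dimethylamino group, would help to separate these.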